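EP3 acylsulfonamide series: aryl change on the sulfonyl

The source may report more compounds than this note shows. Statements on the series, on what has been measured and on what is new or still open speak of the compounds shown alone.

Measured compounds in an assay on isolated protein for displacement of a labelled ligand from prostaglandin E2 receptor EP3 subtype (Homo sapiens), read by scintillation counting, with a stated time of 2 h; on this read-out higher numbers stand for weaker inhibition and lower numbers for stronger inhibition:
compound 1, `O=C(NS(=O)(=O)c1cc(Cl)c(Cl)s1)OC/C=C1\CCCc2cnn(Cc3ccc(Cl)cc3Cl)c21`: 1 nM
compound 2, `O=C(NC/C=C1\CCCc2cnn(Cc3ccc(Cl)cc3Cl)c21)NS(=O)(=O)c1ccc(Cl)cc1`: 4 nM
compound 3, `O=C(NC/C=C1\CCCc2cnn(C3CCN(c4ccc(F)cc4)CC3)c21)NS(=O)(=O)c1cc(Cl)c(Cl)s1`: 1 nM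

Compound 2 has the highest number of the three. The gap to compound 1 and the gap to compound 3 are each beyond the scatter, so compound 2 reads as the weakest of the measured set on this assay. Going by the values given here, no pair in the set differs in only one place, so no single-change step is available to calibrate the next change.

Compound 4, `Cn1cc(S(=O)(=O)NC(=O)NC/C=C2\CCCc3cnn(Cc4ccc(Cl)cc4Cl)c32)cn1`, is compound 2 with 1-methyl-1H-pyrazol-4-yl in place of 4-chlorophenyl on a sulfonyl sulfur. Everything else, including the urea link and the shared core, is unchanged. Among the compounds with values here, with no matched step to lean on, the expectation for this change is a small to moderate weakening, possibly within the scatter, written as a 2.0-fold higher number from compound 2 to compound 4 (0.30 log units; within the scatter). Compound 4 is thus estimated at 8 nM in this assay, with a range of 2 nM to 40 nM.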

Compound 4, inhibition constant: 9 nM
Compound 4: the middle estimate sits 1.1-fold (0.05 log units) below what was measured; the measured number falls inside the stated range.
By their numbers in this assay, from the lowest: compounds 1 and 3 (each within the scatter of the next); then compound 2; then compound 4.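

In this assay, going by these compounds alone, the exchange of 4-chlorophenyl for 1-methyl-1H-pyrazol-4-yl on a sulfonyl sulfur gives the first matched step: a 2.3-fold higher number from compound 2 to compound 4 (0.35 log units; beyond the scatter) with the urea link and the shared core unchanged. At this position, a six-membered aromatic ring of carbon only can therefore give way to a five-membered aromatic ring with 2 hetero atoms at a modest loss. No measurement available here bears on the reason for this step. From the compounds shown here alone, whether a cyclopropyl group or an amine on the sulfonyl sulfur would be accepted remains open. So does whether the same exchange gives a similar step in the setting of compound 3.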